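The source may hold more compounds than are shown below. What is called first, only, known or untested is meant among the compounds shown, and "the series" means these compounds.

Compound 2, `COc1ccc(/C=C(/SCc2ccc(Cl)cc2)C(=O)c2ccc(Cl)cc2)cc1`, is the reference point of this small set. In a functional assay on DU-145 cells (Homo sapiens) for inhibition, read by trypan blue exclusion, with a stated time of 96 h (a higher number here means a weaker inhibitor of growth, a lower number a stronger inhibitor of growth), compound 2 gives 10000 nM. Compound 1, `COc1ccccc1/C=C(/SCc1ccc(Cl)cc1)C(=O)c1ccc(Cl)cc1`, carries 2-methoxyphenyl in place of 4-methoxyphenyl on a double-bonded chain carbon bound to a double-bonded chain carbon, and in this assay compound 1 gives 1000 nM; that is a 10-fold lower number from compound 2 to compound 1 (1.00 log units; beyond the scatter). Compound 3, `COc1ccc(/C=C(/Sc2ccc(Br)cc2)C(=O)c2ccc(Cl)cc2)cc1`, differs from compound 2 by 4-bromophenyl in place of 4-chlorobenzyl on a sulfur, and in this assay compound 3 gives 50000 nM, which is a 5.0-fold higher number from compound 2 to compound 3 (0.70 log units; beyond the scatter), the highest number of the three.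

Compound 4, `COc1ccccc1/C=C(/Sc1ccc(Br)cc1)C(=O)c1ccc(Cl)cc1`, has not yet been measured. Its relation to compound 3 is 2-methoxyphenyl in place of 4-methoxyphenyl on a double-bonded chain carbon bound to a double-bonded chain carbon. This is the same change that turns compound 2 into compound 1, and the place is described in the same words for both pairs; the two pairs rest on cores that differ in the way just told for compound 2 and compound 3. Among the compounds with values here, the only guide is that single earlier step, and it is unknown whether it carries over to the other core. For compound 4 the expected step is a 10-fold lower number from compound 3 to compound 4 (1.00 log units; beyond the scatter), because the earlier move gave a 10-fold lower number from compound 2 to compound 1 (1.00 log units; beyond the scatter). The estimate for compound 4 is 5000 nM, with a range from 1500 nM to 20000 nM.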

Compound 4, concentration for 50% growth inhibition: 10000 nM
Compound 4: the middle estimate sits 2.0-fold (0.30 log units) below what was measured; the range from low to high includes it.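

In this assay, putting 2-methoxyphenyl in place of 4-methoxyphenyl gives a 5.0-fold lower number from compound 3 to compound 4 (0.70 log units; beyond the scatter), so the change carries over to the second core with a size that matches the earlier step within the scatter: the same change on two cores in this assay, a 10-fold lower number (1.00 log units; beyond the scatter) from compound 2 to compound 1 and a 5.0-fold lower number (0.70 log units; beyond the scatter) from compound 3 to compound 4, 2.0-fold (0.30 log units) apart, within the scatter of two such steps. The other change, 4-bromophenyl in place of 4-chlorobenzyl on the sulfur, gives a 10-fold higher number from compound 1 to compound 4 (1.00 log units; beyond the scatter) and also agrees with its earlier counterpart: the same change on two cores in this assay, a 5.0-fold higher number (0.70 log units; beyond the scatter) from compound 2 to compound 3 and a 10-fold higher number (1.00 log units; beyond the scatter) from compound 1 to compound 4, 2.0-fold (0.30 log units) apart, within the scatter of two such steps. Within these four compounds, each change therefore moves the number the same way on both cores, but this rests on only two pairs per change and does not show that either change would act alike on any other core, nor why it acts as it does.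

On these data alone, it remains open whether a hydroxyl group or an amine in place of the methoxy group would follow the same trend, and what a longer chain on the sulfur would do. A 4-chlorophenyl group on the sulfur could also show how much of that step belongs to bromine against chlorine and how much to phenyl against benzyl.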